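A few compounds are considered here, and "the series" means these few. Any claim that something is new, unique, unknown or untested is made for them only; others in the source may bear on it.

Measured compounds in a functional assay on the whole organism (strain Wistar Albino) for inhibition, with Rattus norvegicus as the target, read by paw edema, with a stated time of 4 h, at a dose of 20 mg/kg; a higher number here means more inhibition at the dose given (going by the name of the read-out), a lower number less inhibition:

Compound 1, `COc1ccc(Cl)c(-c2nnc3n2NC(c2ccco2)S3)c1`, gives 25.6%.
Compound 2, `Cc1occc1-c1nnc2n1NC(c1ccco1)S2`, gives 25.9%.
Compound 3, `COc1ccc(Cl)c(-c2nnc3n2NC(c2ccc[nH]2)S3)c1`, gives 20.6%.

Compound 1 and compound 2 carry different cores; the difference between the two cores is not broken down here. In this assay the two values lie within the usual scatter of each other, and compound 3 sits within the scatter of both as well, so no order can be read among the three measured compounds.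

One structural change occurs twice among the compounds shown. From compound 1 to compound 3 the change is 1H-pyrrol-2-yl in place of furan-2-yl on a saturated ring carbon. In this assay the step is a number 5 percentage points lower from compound 1 to compound 3 (within the scatter).

Compound 4, `Cc1occc1-c1nnc2n1NC(c1ccc[nH]1)S2`, has not been measured in this assay. It differs from compound 2 by 1H-pyrrol-2-yl in place of furan-2-yl on a saturated ring carbon, the same change, at the same place, that was made from compound 1 to compound 3. For the measured compounds named here, the expectation for compound 4 therefore rests on that one earlier step: with only a single example of the change available, the step from compound 2 to compound 4 is expected to be a number 4.9 percentage points lower from compound 2 to compound 4 (within the scatter), about as small as the step seen from compound 1 to compound 3 and likewise within the scatter. On that basis compound 4 is estimated to give 21% in this assay, with a likely range from 13% to 29%.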

Compound 4, a percentage reported as inhibition, in the whole organism at one dose (the size of the read-out at that dose, not a potency): 22.7%
Beside the measured number, compound 4's estimate is 1.7 percentage points below it; the range from low to high includes it.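

In this assay, 1H-pyrrol-2-yl in place of furan-2-yl on a saturated ring carbon gives a number 3.2 percentage points lower from compound 2 to compound 4 (within the scatter). Set beside the earlier step on the core of compound 1, the change reads alike on the two cores: the same change on two cores in this assay, a number 5 percentage points lower (within the scatter) from compound 1 to compound 3 and a number 3.2 percentage points lower (within the scatter) from compound 2 to compound 4, 1.8 percentage points apart, within the scatter of two such steps. This agrees with the change carrying over between these two cores without a detectable dependence on the core, but each step lies within the scatter, so it does not show that the change itself moves inhibition in this assay, and two cores cannot establish a rule for the whole series.

The compounds shown hold only furan-2-yl and 1H-pyrrol-2-yl on this saturated ring carbon, which leaves open whether a phenyl ring, a carboxylic acid, an amine or a longer chain there would shift the read-out beyond the scatter. Also open, as far as these compounds go, is how these compounds compare at other doses or times, and whether the two cores themselves differ, as all the numbers here come from one dose at one stated time and give the size of the read-out rather than a potency.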